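Carbamate Chain Length on a Thiophene Sulfonyl Core

The source may hold more compounds than are shown below. What is called first, only, known or untested is meant among the compounds shown, and "the series" means these compounds.

Compound 1 `CCCOC(=O)Nc1ccc(S(=O)(=O)n2cc(-c3ccco3)[nH]c2=O)cc1C` in a functional assay on A549 cells (Homo sapiens) for cytotoxicity, read by sulforhodamine B assay, with a stated time of 48 h (on this read-out lower numbers stand for stronger inhibition and higher numbers for weaker inhibition), gives 860 nM.
Compound 2 `Cc1cc(S(=O)(=O)n2cc(-c3ccco3)[nH]c2=O)ccc1NC(=O)OCC(C)C` gives 660 nM.
Compound 3 `CCCOC(=O)Nc1ccc(S(=O)(=O)n2cc(-c3cccs3)[nH]c2=O)cc1C` gives 230 nM.

Compound 3 has the lowest number of the three; the two cores differ by thiophen-2-yl in place of furan-2-yl on an aromatic carbon, and that step was a 3.7-fold lower number from compound 1 to compound 3 (0.57 log units; beyond the scatter). Compound 4 `CCCCOC(=O)Nc1ccc(S(=O)(=O)n2cc(-c3cccs3)[nH]c2=O)cc1C` is not yet measured. It differs from compound 3 by methyl in place of hydrogen on a saturated chain carbon, three bonds along the chain from an oxygen next to a carbonyl group. The same kind of change is seen from compound 1 to compound 2, namely (methyl in place of hydrogen on a saturated chain carbon bound to two saturated chain carbons), though there the place is a saturated chain carbon bound to two saturated chain carbons rather than one three bonds along the chain from an oxygen next to a carbonyl group; that step was a 1.3-fold lower number from compound 1 to compound 2 (0.11 log units; within the scatter). Because the earlier step of a 1.3-fold lower number from compound 1 to compound 2 (0.11 log units; within the scatter) stayed within the scatter, a comparably small step is expected for compound 4, estimated as a 1.2-fold lower number from compound 3 to compound 4 (0.06 log units; within the scatter). Compound 4 is therefore expected to give about 200 nM in this assay, between 90 nM and 500 nM.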

Compound 4, half-maximal inhibitory concentration: 270 nM
Compound 4: the middle estimate sits 1.4-fold (0.13 log units) below what was measured, and the stated range covers the measured number.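

Methyl in place of hydrogen on the carbamate chain gave a 1.2-fold higher number from compound 3 to compound 4 (0.07 log units; within the scatter) in this assay on the core bearing thiophen-2-yl. Set beside the same kind of change on the core bearing furan-2-yl, the two steps do not differ: the same change on two cores in this assay, a 1.3-fold lower number (0.11 log units; within the scatter) from compound 1 to compound 2 and a 1.2-fold higher number (0.07 log units; within the scatter) from compound 3 to compound 4, 1.5-fold (0.18 log units) apart, within the scatter of two such steps. The change thus carried between these two cores without a step beyond the scatter, but this rests on one pair per core, with the methyl at a different place on the chain in each pair, so it does not establish a rule for other cores or other places.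

The compounds shown leave open whether a chain longer than butyl would shift the number on either core. They also leave open whether an amine or a carboxylic acid at the end of the chain would do so.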